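The source may hold more compounds than are shown below. What is called first, only, known or untested is meant among the compounds shown, and "the series" means these compounds.

Measured in a functional assay on ECa-109 cells for inhibition, with ECa-109 cell line (Homo sapiens) as the target, read by sulforhodamine B assay; on this read-out higher numbers stand for weaker inhibition and lower numbers for stronger inhibition:
- Compound 1 `Cc1ccc(NC2=CC(=O)c3c(nc4n3[C@H]3OC[C@@H](O)[C@H]3OC4)C2=O)cc1C`: 4090 nM
- Compound 2 `COc1ccccc1NC1=CC(=O)c2c(nc3n2[C@H]2OC[C@@H](O)[C@H]2OC3)C1=O`: > 4000 nM, a limit of the assay and not a number
- Compound 3 `COc1ccc(NC2=CC(=O)c3c(nc4n3[C@H]3OC[C@@H](O)[C@H]3OC4)C2=O)cc1`: 3410 nM

Going by the values given here, compound 3 and compound 1 are the only two with real numbers, and they cannot be told apart. Compound 4 `CCCc1ccc(NC2=CC(=O)c3c(nc4n3[C@H]3OC[C@@H](O)[C@H]3OC4)C2=O)cc1` is compound 3 with one group exchanged: propyl in place of methoxy on an aromatic carbon.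

Two measured steps changed the aromatic group on the amine nitrogen: a 1.2-fold lower number from compound 1 to compound 3 (0.08 log units; within the scatter), and an at least 1.1-fold lower number from compound 2 to compound 3 (0.06 log units; that floor lies within the scatter). Neither shows a change beyond the scatter, so no clear shift is expected in this assay. The expected result is a 1.1-fold higher number from compound 3 to compound 4 (0.02 log units; within the scatter). For compound 4 the estimated value is 3600 nM, with an expected range of 1600 nM to 8000 nM.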

Compound 4, half-maximal inhibitory concentration: > 4000 nM
Compound 4: no number, only a limit (the forecaster's own chance of this, stated with the estimate: 30%); middle value at least 1.1-fold (0.04 log units) from the limit.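

In this assay, propyl in place of methoxy on the aromatic carbon para to a large group gives an at least 1.1-fold higher number from compound 3 to compound 4 (0.06 log units; that floor lies within the scatter). Going by these compounds, compound 4 gives > 4000 nM, which is a limit of the assay and not a number, so the full size of this step is unknown, and the steps from compound 1 and compound 2 to compound 4 cannot be read. A carbon chain at this position thus gives the same limit as compound 2: the limit of > 4000 nM in this assay, at which 2 of the 4 values shown sit.

On these data alone, how far compound 4 lies past that limit stays open. So does whether an amine or a carboxylic acid at this position would give a readable number.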